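A few compounds are considered here, and "the series" means these few. Any claim that something is new, unique, unknown or untested is made for them only; others in the source may bear on it.

Measured so far:
- compound 1, `CS(=O)(=O)c1cc(Cl)ccc1NCC1=NCCN1`: in an assay on CHO cells for binding affinity to Alpha-2C adrenergic receptor (Homo sapiens), read by radioligand binding (on this read-out lower numbers stand for stronger inhibition and higher numbers for weaker inhibition), compound 1 gives 3980 nM
- compound 2, `CS(=O)(=O)c1ccc(Cl)cc1NCC1=NCCN1`: in this assay compound 2 gives 4790 nM

Among the compounds with values here, compound 2 stands at a value that lies within the usual scatter of the value of compound 1, so the two cannot be told apart on these numbers; both sit in the weak range, and no step between measured compounds is available to calibrate the series.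

Compound 3, `CS(=O)(=O)c1ccc(C(F)(F)F)cc1NCC1=NCCN1`, is not yet measured. It differs from compound 2 by trifluoromethyl in place of chloro on an aromatic carbon. Within the data shown here, with no measured step of this kind to lean on, the expectation for this assay is a change of no more than the scatter, in either direction, with a slight lean toward a weaker number. The step from compound 2 to compound 3 is therefore expected to be about a 1.1-fold higher number from compound 2 to compound 3 (0.06 log units; within the scatter). Compound 3 is estimated at 5500 nM, with a range from 1800 nM to 17000 nM.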

Compound 3, inhibition constant: < 5020 nM
Compound 3 gave a limit, no number; the forecaster's own chance of this, stated with the estimate: 10%; middle value at least 1.0-fold (0.03 log units) away from the limit.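

In this assay compound 3 gives only a limit, < 5020 nM, and not a number, so the step between compound 2 and compound 3 cannot be read. On these data alone, whether trifluoromethyl in place of chloro on an aromatic carbon shifts the value at all remains open.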